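Chloro for fluoro on the outer ring: expected potency

The source may report more compounds than this note shows. Statements on the series, on what has been measured and on what is new or still open speak of the compounds shown alone.

Measured so far in a functional assay on MCF7 cells (Homo sapiens) for cytotoxicity, read by MTT assay, with a stated time of 72 h; a higher number here means a weaker inhibitor, a lower number a stronger inhibitor:
compound 1 `O=C(Nc1ccc(Oc2ccnc3[nH]ccc23)cc1)c1ccc(-c2ccc(Cl)cc2)cn1` gives > 10000 nM, a limit of the assay.
compound 2 `COc1ccc(-c2ccc(C(=O)Nc3ccc(Oc4ccnc5[nH]ccc45)c(F)c3)nc2)cc1` gives 10100 nM.
compound 3 `O=C(Nc1ccc(Oc2ccnc3[nH]ccc23)c(F)c1)c1ccc(-c2ccc(F)cc2)cn1` gives > 10000 nM, a limit of the assay.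

Compound 3 stands at the limit of this assay: its value > 10000 nM is a limit, not a number. Compound 2 gives 10100 nM. Going by the values given here, the one measured step, a step that the limit leaves unreadable from compound 2 to compound 3, is therefore of unreadable size, and it concerns a methoxy-to-fluoro exchange rather than the change at hand. The change under consideration is chloro in place of fluoro on an aromatic carbon, giving compound 4 `O=C(Nc1ccc(Oc2ccnc3[nH]ccc23)c(F)c1)c1ccc(-c2ccc(Cl)cc2)cn1`. Among the compounds with values here, no measured step bears directly on a chloro-for-fluoro exchange. Compound 1, which also carries the chloro group, sits at the limit described by the limit of > 10000 nM in this assay, at which 2 of the 3 values shown sit. The values shown give no ground for expecting compound 4 to move beyond the scatter in this assay, and the most likely outcome is again a limit. Compound 4 is estimated at 15000 nM, with a range from 5000 nM to 50000 nM. The expected step is a step that the limit leaves unreadable from compound 3 to compound 4.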

Compound 4, half-maximal inhibitory concentration: > 10000 nM
Compound 4: only a limit was reported (the forecaster's own chance of this, stated with the estimate: 70%); the middle value does not contradict the limit.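

In this assay, going by these compounds alone, compound 4 gives > 10000 nM, a limit of the assay, so no step linking compound 4 to compound 1, compound 2 or compound 3 can be read. The compounds shown leave open whether 4-fluorophenyl to 4-chlorophenyl changes cytotoxicity at all, as most of the series sits at one value: the limit of > 10000 nM in this assay, at which 3 of the 4 values shown sit.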